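From 4-chlorophenyl to 3-cyanophenyl on a shared core

This account rests on a few compounds, and the source may have more. Where it says the series, first, only, none or still open, it means among the compounds named here.

Measured so far in a functional assay on MDA-MB-231 cells (Homo sapiens) for antiproliferative activity, read by MTT assay, with a stated time of 72 h; a higher number here means a weaker inhibitor, a lower number a stronger inhibitor:
compound 1 `O=C(CCc1cccc2c1B(O)OC2)Nc1cccc(-c2cccc(Cl)c2)c1` (250 nM)
compound 2 `O=C(CCc1cccc2c1B(O)OC2)Nc1cccc(-c2ccc(Cl)cc2)c1` (260 nM)

Compound 2 stands level with compound 1 on these numbers. Going by the values given here, the only measured step is a 1.0-fold higher number from compound 1 to compound 2 (0.02 log units; within the scatter) and it places 4-chlorophenyl where 3-chlorophenyl stood on an aromatic carbon. Still unmeasured is compound 3 `N#Cc1cccc(-c2cccc(NC(=O)CCc3cccc4c3B(O)OC4)c2)c1` and it departs from compound 2 by one exchange (3-cyanophenyl in place of 4-chlorophenyl on an aromatic carbon) in which 3-cyanophenyl takes the place of 4-chlorophenyl on an aromatic carbon, meta to a large group. No measured compound carries a nitrile, so the size of this exchange is not shown directly. Among the compounds with values here, the one measured step bears on it only in part, since it swaps one chlorophenyl for another. Resting on compound 2 at 260 nM and on the small step of a 1.0-fold higher number from compound 1 to compound 2 (0.02 log units; within the scatter) as the only guide, no step beyond the scatter is expected in this assay and no direction is favoured. The estimate amounts to a 1.1-fold higher number from compound 2 to compound 3 (0.03 log units; within the scatter) as the expected step. For compound 3 the estimated value is 280 nM with an expected range from 110 nM to 700 nM in this measurement.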

Compound 3, half-maximal inhibitory concentration: 110 nM
Estimate against measurement, compound 3: 2.5-fold (0.41 log units) above; the measured number falls inside the stated range.
By their numbers in this assay, from the lowest: compound 3; then compounds 1 and 2 (each within the scatter of the next).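

In this assay, the two chlorophenyl compounds showed only that the place of the chlorine made no difference beyond the scatter, so this ring had not yet moved the number. Going by these compounds alone, the nitrile gives the first step beyond the scatter, both against 4-chlorophenyl (a 2.4-fold lower number from compound 2 to compound 3 (0.37 log units; beyond the scatter)) and, more cleanly, as cyano in place of chloro at the same ring position (a 2.3-fold lower number from compound 1 to compound 3 (0.36 log units; beyond the scatter)), and the two steps are modest and close in size, so the identity of the group at this position counts for more here than the chlorine's place did. Nothing available explains why the nitrile differs from the chlorine in this read-out.

Three compounds cannot show whether the lower number belongs to the nitrile alone or would also appear with another group on this ring, such as an amine, a carboxylic acid or a methoxy group. They also leave open whether the same exchange would give a step of similar size on a longer chain between the amide and the rest of the shared core.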